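The source may report more compounds than this note shows. Statements on the series, on what has been measured and on what is new or still open speak of the compounds shown alone.

Measured so far:
Compound 1, `O=C1/C(=C/c2ccccc2)NS(=O)(=O)c2ccccc21` — 660 nM
Compound 2, `COc1ccccc1/C=C1\NS(=O)(=O)c2ccccc2C1=O` — 2590 nM

In an assay for inhibition of alkaline phosphatase, tissue-nonspecific isozyme (Homo sapiens), read by spectrophotometry, with stated times of 10 min and 20 min (a lower number here means a stronger inhibitor, a higher number a weaker inhibitor), compound 1 gives 660 nM, the lower of the two numbers seen; compound 2, which carries a methoxy group on another carbon of the same ring, gives 2590 nM. Going by the values given here, the one step measured so far, a 3.9-fold higher number from compound 1 to compound 2 (0.59 log units; beyond the scatter), shows that adding a methoxy group to that ring weakened inhibition by a modest amount.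

Compound 3, `COc1cccc(/C=C2\NS(=O)(=O)c3ccccc3C2=O)c1`, has not been measured. It differs from compound 1 by methoxy in place of hydrogen on an aromatic carbon, with the methoxy placed meta to a large group. Among the compounds with values here, the only related step, a 3.9-fold higher number from compound 1 to compound 2 (0.59 log units; beyond the scatter), concerns the same group on the same ring, so a weakening in this assay of similar or smaller size is expected, the direction being uncertain because only compound 2 informs it. Compound 3 is therefore estimated at 1300 nM, within 500 nM to 3500 nM, which would mean an expected step of a 2.0-fold higher number from compound 1 to compound 3 (0.29 log units; within the scatter).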

Compound 3, half-maximal inhibitory concentration: > 200000 nM
Compound 3 ended at the assay's limit (the forecaster's own chance of this, stated with the estimate: 3%); at least 150-fold (2.18 log units) between middle value and limit.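

Placed meta to a large group, methoxy in place of hydrogen gives an at least 300-fold higher number from compound 1 to compound 3 (2.48 log units; beyond the scatter) in this assay, a large step, whereas the same group on another carbon of the ring, in compound 2, gave only a modest one. On this ring, then, where the methoxy sits matters as well as whether it is there: the same change weakens inhibition modestly at one carbon and far more at the other. The result for compound 3 is a limit of the assay and not a number, so the true size of this step remains unknown: the limit of > 200000 nM in this assay, at which 1 of the 3 values shown sits.

On these data alone, whether a smaller group such as a fluorine or a hydroxyl on this same carbon would weaken inhibition as sharply remains open. What lies behind the strong dependence on position also remains open. Nothing shown speaks to it.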